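Iodo to Trifluoromethyl on a Second Core

The compounds below may be only part of what the source reports. "The series", "measured", "known", "first", "only" and "open" are said of these compounds alone.

Compound 1 `O=C(N/N=C/C1=C(Cl)c2ccccc2CCC1)c1cccc(I)c1` and compound 2 `O=C(N/N=C/C1=C(Cl)c2ccccc2CCC1)c1cccc(C(F)(F)F)c1` share one core, while compound 3 `Cc1cc2c(cc1C)C(Cl)=C(/C=N/NC(=O)c1cccc(I)c1)CCC2` and compound 4 `Cc1cc2c(cc1C)C(Cl)=C(/C=N/NC(=O)c1cccc(C(F)(F)F)c1)CCC2` share another; how the two cores differ is not broken down here. In a functional assay on HeLa cells (Homo sapiens) for inhibition, read by sulforhodamine B assay, with a stated time of 48 h (on this read-out higher numbers stand for weaker inhibition of growth and lower numbers for stronger inhibition of growth), compound 1 gives 6300 nM. In this assay compound 2 gives 16300 nM, so that a 2.6-fold higher number from compound 1 to compound 2 (0.41 log units; beyond the scatter) (trifluoromethyl in place of iodo on an aromatic carbon). For compound 3, this assay reports only a limit, > 100000 nM. The change from compound 3 to compound 4 is the same kind of change: trifluoromethyl in place of iodo on an aromatic carbon. Since the earlier step of a 2.6-fold higher number from compound 1 to compound 2 (0.41 log units; beyond the scatter) moved the number toward weaker inhibition and compound 3 already sits at the limit of > 100000 nM in this assay, at which 1 of the 3 values shown sits, compound 4 is expected to remain at or beyond that limit, an estimated step that the limit leaves unreadable from compound 3 to compound 4. Compound 4 is estimated at 250000 nM, most likely between 100000 nM and 600000 nM.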

Compound 4, concentration for 50% growth inhibition: 6800 nM
Compound 4: the middle estimate sits 37-fold (1.57 log units) above what was measured; measured number outside the range, below it.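

In this assay, trifluoromethyl in place of iodo gives an at least 14-fold lower number from compound 3 to compound 4 (1.16 log units; beyond the scatter), so the change did not carry over from one core to the other, and its direction reversed: the same change on two cores in this assay, a 2.6-fold higher number (0.41 log units; beyond the scatter) from compound 1 to compound 2 and an at least 14-fold lower number (1.16 log units; beyond the scatter) from compound 3 to compound 4, at least 38-fold (1.58 log units) apart, beyond the scatter of two such steps Compound 3 stands at a limit and not at a number, so the new step gives only a minimum size: the limit of > 100000 nM in this assay, at which 1 of the 4 values shown sits. These two pairs show that the outcome of this change can depend on the core, but they do not show which difference between the cores matters or what would happen on a further core.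

The compounds shown leave open how other groups on this aromatic carbon, such as a nitrile, a methyl or a carboxylic acid, would behave on each core. They also leave open whether any such group would give the same reversal.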